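A few compounds are considered here, and "the series" means these few. Any claim that something is new, unique, unknown or untested is made for them only; others in the source may bear on it.

Measured compounds:
Compound 1 `COc1ccc(C2=C(c3cc(OC)c(OC)c(OC)c3)C(=O)C(OC(C)=O)C2)cc1OC(C)C` gives > 100 ug/mL in an ADME assay on MIA PaCa-2 cells (Homo sapiens) for cytotoxicity, read by MTT assay, with a stated time of 72 h (on this read-out lower numbers stand for stronger inhibition and higher numbers for weaker inhibition), a value that is a limit of the assay.
Compound 2 `COc1ccc(C2=C(c3cc(OC)c(OC)c(OC)c3)C(=O)C(OC(C)=O)C2)cc1F` gives 39.5 ug/mL.
Compound 3 `COc1ccc(C2=C(c3cc(OC)c(OC)c(OC)c3)C(=O)C(O)C2)cc1F` gives 64 ug/mL.

Compound 2 and compound 1 differ by isopropoxy in place of fluoro on an aromatic carbon, and this change gave an at least 2.5-fold higher number from compound 2 to compound 1 (0.40 log units; beyond the scatter), with compound 1 sitting at the limit of > 100 ug/mL in this assay, at which 1 of the 3 values shown sits. Compound 2 and compound 3 differ by hydrogen in place of acetyl on an oxygen on a saturated carbon, a step of a 1.6-fold higher number from compound 2 to compound 3 (0.21 log units; within the scatter). Compound 4 `COc1ccc(C2=C(c3cc(OC)c(OC)c(OC)c3)C(=O)C(O)C2)cc1OC(C)C` has not been measured in this assay. It differs from compound 3 by isopropoxy in place of fluoro on an aromatic carbon, the same change, at a place described in the same words, as that from compound 2 to compound 1. That earlier step gave an at least 2.5-fold higher number from compound 2 to compound 1 (0.40 log units; beyond the scatter). On that basis compound 4 is expected to show a 2.5-fold higher number from compound 3 to compound 4 (0.40 log units; beyond the scatter), quite possibly reaching a limit. Compound 4 is therefore estimated at 160 ug/mL, between 80 ug/mL and 400 ug/mL.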

Compound 4, half-maximal inhibitory concentration: > 100 ug/mL
Compound 4: no number, only a limit; the forecaster's own chance of this, stated with the estimate: 65%; the middle value does not contradict the limit.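

In this assay compound 4 gives > 100 ug/mL, which is a limit of the assay and not a number. On the core of compound 3, isopropoxy in place of fluoro gave an at least 1.5-fold higher number from compound 3 to compound 4 (0.19 log units; that floor lies within the scatter), which does not contradict the rise seen on the core of compound 2, although this floor alone does not establish a rise beyond the scatter. Whether the change carries over from one core to the other with the same size stays unsettled: the same change on two cores in this assay, an at least 2.5-fold higher number (0.40 log units; beyond the scatter) from compound 2 to compound 1 and an at least 1.5-fold higher number (0.19 log units; that floor lies within the scatter) from compound 3 to compound 4; the limit leaves it open whether they differ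

The step between compound 1 and compound 4 cannot be read, as both values are limits. The compounds shown also leave open how an ethoxy group or an amine in place of fluoro would read in this assay.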